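Moving from a Fluorine to an Ethyl Group on the Benzamide

The compounds below may be only part of what the source reports. "The series", "measured", "known", "first", "only" and "open" are said of these compounds alone.

Of the compounds shown here, two of a shared core have been measured in a functional assay on HepG2 cells (Homo sapiens) for antiproliferative activity, read by CCK-8 assay, with a stated time of 72 h; on this read-out higher numbers stand for weaker inhibition and lower numbers for stronger inhibition. Compound 1 `O=C(Nc1cccc(-c2oc3cc(-c4ccc(F)cc4)ccc3c(=O)c2O)c1)c1ccccc1F` gives 10100 nM. Going by the values given here, compound 2 `O=C(Nc1cccc(-c2oc3cc(-c4ccc(F)cc4)ccc3c(=O)c2O)c1)c1cccc(F)c1` gives 15500 nM, the highest of the two numbers; the only measured step, a 1.5-fold higher number from compound 1 to compound 2 (0.19 log units; within the scatter), shows that shifting the fluorine on the benzamide ring did not change the read-out beyond the scatter. Compound 3 `CCc1ccc(C(=O)Nc2cccc(-c3oc4cc(-c5ccc(F)cc5)ccc4c(=O)c3O)c2)cc1` carries a different change at the same place: 4-ethylphenyl in place of 3-fluorophenyl on a carbonyl carbon. Among the compounds with values here, the single measured step concerns a fluorine moving around the ring and says little about replacing it with an ethyl group, so there is no firm basis for a direction. Without such a basis, no step beyond the scatter is expected, and the step is estimated as a 1.3-fold lower number from compound 2 to compound 3 (0.11 log units; within the scatter). Compound 3 is therefore expected to give about 12000 nM in this assay, with a likely range from 4000 nM to 36000 nM.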

Compound 3, half-maximal inhibitory concentration: 20600 nM
Estimate against measurement, compound 3: 1.7-fold (0.23 log units) below; low and high end bracket the measured number.
By their numbers in this assay, from the lowest: compounds 1, 2 and 3 (each within the scatter of the next, the first and the last beyond it).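

In this assay, going by these compounds alone, 4-ethylphenyl in place of 3-fluorophenyl gives a 1.3-fold higher number from compound 2 to compound 3 (0.12 log units; within the scatter) and so cannot be told apart from compound 2, while the same group in place of 2-fluorophenyl gives a 2.0-fold higher number from compound 1 to compound 3 (0.31 log units; beyond the scatter) and is the first step here to clear the scatter, though only modestly. A benzamide ring with no fluorine, carrying an ethyl group instead, thus stays close to the two fluorinated compounds, and compound 2 lies within the scatter of both others, so the three do not split into clear tiers. Nothing available explains the small gap between compound 1 and compound 3.

As far as these compounds go, what a longer chain, an amine or a carboxylic acid on this ring would do remains open. So does whether any group at this place can move the number far beyond the scatter.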